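Ether variants at the aromatic-ring oxygen of compound 1

The source may hold more compounds than are shown below. What is called first, only, known or untested is meant among the compounds shown, and "the series" means these compounds.

Compound 1 `COc1ccc(/C=C/C(=O)c2ccc(OC)c3c2OC(C)(C)C=C3)cc1O` carries hydrogen on an oxygen on an aromatic ring, and in a functional assay on K562 cells (Homo sapiens) for cytotoxicity, read by MTT assay (on this read-out lower numbers stand for stronger inhibition and higher numbers for weaker inhibition), compound 1 gives 630 nM. Compound 2 `COc1ccc(/C=C/C(=O)c2ccc(OC)c3c2OC(C)(C)C=C3)cc1OCC=C(C)C` has 3-methylbut-2-en-1-yl on that oxygen. In this assay compound 2 gives > 10000 nM, which is a limit and not a number. Compound 3 `C#CCOc1cc(/C=C/C(=O)c2ccc(OC)c3c2OC(C)(C)C=C3)ccc1OC` has propargyl on the same oxygen. In this assay compound 3 gives > 10000 nM, again a limit. Both steps, an at least 15-fold higher number from compound 1 to compound 2 (1.20 log units; beyond the scatter) and an at least 15-fold higher number from compound 1 to compound 3 (1.20 log units; beyond the scatter), are large, while a step that the two limits leave unreadable from compound 2 to compound 3. Compound 4 `COc1ccc(/C=C/C(=O)c2ccc(OC)c3c2OC(C)(C)C=C3)cc1OCCO` differs from compound 2 as hydroxymethyl in place of 2-methylprop-1-en-1-yl on a saturated chain carbon bound to an oxygen on an aromatic ring. For the measured compounds named here, compound 4 stays an ether of that oxygen, and a weak result is expected for compound 4 because both measured ethers sit at the limit of > 10000 nM in this assay, at which 2 of the 3 values shown sit, though the hydroxymethyl has no precedent here. Compound 4 is expected near 6000 nM, range 1500 nM to 25000 nM. The expected step is an at least 1.6-fold lower number from compound 2 to compound 4 (0.22 log units; that floor lies within the scatter).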

Compound 4, half-maximal inhibitory concentration: 8750 nM
Compound 4: middle estimate off by 1.5-fold (0.16 log units), on the low side; measured number inside the range.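

In this assay, for the compounds shown here, compound 4 gives 8750 nM, the first actual number for an ether at this oxygen. Compound 2 and compound 3 gave only limits. The loss on etherification now has a size, a 14-fold higher number from compound 1 to compound 4 (1.14 log units; beyond the scatter), and it persists with 2-hydroxyethyl, which brings a hydrogen-bond donor. Against the earlier ethers the steps read an at least 1.1-fold lower number from compound 2 to compound 4 (0.05 log units; that floor lies within the scatter) and an at least 1.1-fold lower number from compound 3 to compound 4 (0.05 log units; that floor lies within the scatter), so the hydroxymethyl end gives no firm gain. Open, going by these compounds, is whether a shorter methyl ether, or an amine or carboxylic acid at the chain end, would recover the value of compound 1.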